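Extending the aryl ether of compound 2 to a benzyl ether

A few compounds are considered here, and "the series" means these few. Any claim that something is new, unique, unknown or untested is made for them only; others in the source may bear on it.

Two compounds carry the shared core with a pentyl chain on the ring nitrogen. Compound 1 `CCCCCn1c(N)nc2c(C)cccc21` gives 1130 nM in an assay on HEK293 cells for agonist activity at Toll-like receptor 8 (Homo sapiens), read by reporter gene assay; on this read-out higher numbers stand for an effect only at larger amounts of compound and lower numbers for an effect already at smaller amounts. Compound 2 `CCCCCn1c(N)nc2c(OC)cccc21` gives 3740 nM in this assay. The step of a 3.3-fold higher number from compound 1 to compound 2 (0.52 log units; beyond the scatter) is the only one measured in the series, and on it compound 2 stands as the higher of the two numbers.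

Compound 3 `CCCCCn1c(N)nc2c(OCc3ccccc3)cccc21` differs from compound 2 by phenyl in place of hydrogen on a saturated chain carbon bound to an oxygen on an aromatic ring. Going by the values given here, no measured step covers an extension of this kind; the one step at hand, methyl to methoxy, only shows that a change at this aromatic carbon moved the number beyond the scatter, in the direction of a higher value. Whether a phenyl on the ether carbon moves the number further up, brings it back down, or leaves it within the scatter cannot be read from compound 1 and compound 2 alone.

The step of a 1.2-fold lower number from compound 2 to compound 3 (0.10 log units; within the scatter) is therefore expected to be small, with a wide range in both directions. Compound 3 is estimated at 3000 nM, between 700 nM and 13000 nM.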

Compound 3, half-maximal effective concentration: "not active" (no number reported)
The entry for compound 3 holds no number; the estimate stays without a comparison.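

Going by these compounds alone, compound 3 is entered as not active with no number, so no step from compound 2 to compound 3 can be read. Nothing measured here bears on this result. The compounds shown leave open what number, if any, a benzyl ether at this aromatic carbon would give, and whether other ethers there retain a measurable effect.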